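Lengthening the Amine Substituent of Compound 1

The source may report more compounds than this note shows. Statements on the series, on what has been measured and on what is new or still open speak of the compounds shown alone.

Compound 1 `CC(=O)N1CCC(c2ccc(-c3cc(C(=O)O)cc4cc(-c5ccc(C(F)(F)F)cc5)ccc34)cc2)CC1` was tested in a functional assay on the whole organism (strain ICR) for inhibition, with Mus musculus as the target, with stated times of 7 days and 3 h, at a dose of 10 umol/kg by the intraperitoneal route (on this read-out higher numbers stand for more inhibition at the one dose given (going by the name of the read-out) and lower numbers for less inhibition), where compound 1 gives 92.4%. Among the three numbers recorded this is the highest. In this assay compound 2 `O=C(O)c1cc(-c2ccc(C3CCNCC3)cc2)cc(-c2cn(-c3ccc(C(F)(F)F)cc3)nn2)c1` gives 55.1%, a value beyond the scatter below compound 1, and compound 3 `O=C(O)c1cc(O)c2ccc(-c3ccc(C(F)(F)F)cc3)cc2c1` gives 35.2%, the number furthest from compound 1. Compound 4 `C#CCCCCN1CCC(c2ccc(-c3cc(C(=O)O)cc4cc(-c5ccc(C(F)(F)F)cc5)ccc34)cc2)CC1` has not been measured. It differs from compound 1 in one place: hex-5-yn-1-yl in place of acetyl on an amine nitrogen in a ring. Among the compounds with values here, no measured pair shows this change, so nothing observed fixes its direction. The step of a number 20.4 percentage points lower from compound 1 to compound 4 (beyond the scatter) is expected to be downward and of moderate size, beyond the scatter. Compound 4 is estimated to give 72% in this assay, with a range from 45% to 95%.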

Compound 4, a percentage reported as inhibition, in the whole organism at one dose (the size of the read-out at that dose, not a potency): 9.6%
The estimate for compound 4 lay 62.4 percentage points above the measured number; the whole stated range lies above it.
By their numbers in this assay, from the lowest: compound 4; then compound 3; then compound 2; then compound 1.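

Replacing acetyl with hex-5-yn-1-yl on the amine nitrogen in a ring gives, in this assay, a number 82.8 percentage points lower from compound 1 to compound 4 (beyond the scatter). This first step at this position shows that the read-out depends strongly on the group carried by this nitrogen, and that this change does not preserve the level of compound 1. Nothing at hand accounts for the size of the step.

From the compounds shown here alone, the swap changes chain length, the triple bond and the carbonyl together, so their shares remain open. A saturated hexyl chain or a propanoyl group could separate them.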